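Taking one methoxy group away from compound 2

This account rests on a few compounds, and the source may have more. Where it says the series, first, only, none or still open, it means among the compounds named here.

Compound 2 `CCOC(=O)/C=C/c1cc(OC)c(OC(=O)c2nc(C)c(C)nc2C)c(OC)c1` stands at the low end of the three numbers measured in a functional assay on EA.hy 926 cells (Homo sapiens) for cytotoxicity, read by MTT assay, with stated times of 24 h and 12 h (on this read-out lower numbers stand for an effect already at smaller amounts and higher numbers for an effect only at larger amounts of compound), where compound 2 gives 21400 nM. Compound 3 `COc1cc(/C=C/C(=O)O)cc(OC)c1OC(=O)c1nc(C)c(C)nc1C` gives 34700 nM, and the step of a 1.6-fold higher number from compound 2 to compound 3 (0.21 log units; within the scatter) is too small to separate the two. Compound 1 `CCOC(=O)/C=C/c1cc(OC)ccc1OC(=O)c1nc(C)c(C)nc1C`, which carries one methoxy group rather than two, gives 105000 nM, a number that lies clearly beyond the scatter from compound 2.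

Compound 4 `CCOC(=O)/C=C/c1ccc(OC(=O)c2nc(C)c(C)nc2C)c(OC)c1` is obtained from compound 2 by the change (hydrogen in place of methoxy on an aromatic carbon). For the measured compounds named here, no measured step follows exactly this change: the only step on record, a 1.6-fold higher number from compound 2 to compound 3 (0.21 log units; within the scatter), concerns a different part of the molecule. The single-methoxy compound 1 does sit well above compound 2, yet it differs from compound 2 in more than one place, so its value is only a loose hint. A moderate rise is therefore expected, a 2.0-fold higher number from compound 2 to compound 4 (0.29 log units; within the scatter), with wide uncertainty. Compound 4 is estimated at 42000 nM, within a range from 15000 nM to 120000 nM.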

Compound 4, half-maximal effective concentration: 38600 nM
Beside the measured number, compound 4's estimate is 1.1-fold (0.04 log units) above it; low and high end bracket the measured number.
By their numbers in this assay, from the lowest: compounds 2, 3 and 4 (each within the scatter of the next); then compound 1.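

In this assay, for the compounds shown here, replacing this methoxy group with a hydrogen on the aromatic carbon gives a 1.8-fold higher number from compound 2 to compound 4 (0.26 log units; within the scatter), the first direct reading of this change at this position. The step lies within the scatter, so this assay cannot separate compound 4 from compound 2, and the second methoxy group shows no measurable contribution to the number here. Nothing available explains this outcome or links it to a property of the group.

The compounds shown leave open whether a different group on this aromatic carbon, such as a hydroxyl, an amine or a longer alkoxy chain, would move the number beyond the scatter. They also leave open whether the same swap would read the same way on the carboxylic acid form, compound 3.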